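Working notes: outlook for compound 3 in the Capan-2 series

The source may hold more compounds than are shown below. What is called first, only, known or untested is meant among the compounds shown, and "the series" means these compounds.

Measured so far:
compound 1, `O=S(=O)(NCCNCc1cccc2ccccc12)c1cc(C(F)(F)F)cc(C(F)(F)F)c1`: 21000 nM
compound 2, `O=S(=O)(NCCCNCc1ccc(Cl)c(C(F)(F)F)c1)c1cc(C(F)(F)F)cc(C(F)(F)F)c1`: 9100 nM

In a functional assay on Capan-2 cells (Homo sapiens) for inhibition, read by MTT assay, with a stated time of 72 h (a lower number here means a stronger inhibitor of growth, a higher number a weaker inhibitor of growth), compound 2 gives 9100 nM, the lowest of the two numbers recorded. Its nearest neighbour is compound 1, which gives 21000 nM; that gap lies beyond the scatter, so compound 2 is the stronger growth inhibitor of the two. For the measured compounds named here, the two measured compounds differ in more than one place, so no single-change step between them is available, and the shorter chain and the naphthyl group of compound 1 cannot be separated from each other on these numbers.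

Compound 3, `COc1cccc(CNCCCNS(=O)(=O)c2cc(C(F)(F)F)cc(C(F)(F)F)c2)c1`, has not yet been measured. It differs from compound 2 in one place: 3-methoxyphenyl in place of 4-chloro-3-(trifluoromethyl)phenyl on a saturated chain carbon bound to an amine nitrogen. Going by the values given here, nothing among the measured compounds covers this exchange directly, so the expectation rests on compound 2 alone and on the general run of such exchanges, where the halogenated aryl groups have so far given the lower numbers.

The step expected from compound 2 to compound 3 in this assay is a 1.6-fold higher number from compound 2 to compound 3 (0.22 log units; within the scatter), a modest weakening that may fall within the scatter. Compound 3 is estimated at 15000 nM, with a range from 6000 nM to 40000 nM.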

Compound 3, concentration for 50% growth inhibition: 6400 nM
For compound 3 the middle estimate is 2.3-fold (0.37 log units) above the measured one; the measured number falls inside the stated range.
By their numbers in this assay, from the lowest: compounds 3 and 2 (each within the scatter of the next); then compound 1.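

In this assay, for the compounds shown here, the exchange of 4-chloro-3-(trifluoromethyl)phenyl for 3-methoxyphenyl on a saturated chain carbon bound to an amine nitrogen gives the first single-place step: a 1.4-fold lower number from compound 2 to compound 3 (0.15 log units; within the scatter). This position therefore tolerates an aryl group with no chlorine or fluorine, and the smaller group with its one hydrogen-bond acceptor reads the same as the larger group with none, so for this pair the halogenated substitution is not needed to keep growth inhibition at this level. No supporting measurement bears on why the two groups read alike.

As far as these compounds go, it remains open whether an unsubstituted phenyl, a pyridine ring or an aryl group carrying a carboxylic acid would also hold at this position, and one such exchange would show whether the tolerance extends beyond this single pair. Compound 1 still differs from the others in more than one place, so the effect of chain length needs a direct pair, such as the 3-methoxyphenyl group carried on a shorter or a longer chain.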